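The source may hold more compounds than are shown below. What is called first, only, known or untested is meant among the compounds shown, and "the series" means these compounds.

Measured in an ADME assay on liver for metabolic stability, with Liver microsome (Homo sapiens) as the target, using microsomes and NADPH, with a stated time of 30 min, tested at 0.5 uM; on this read-out lower numbers stand for slow clearance and higher numbers for fast clearance:
- compound 1 `CN1CCN(CCOc2nn(-c3ccccc3F)c3ccc(F)cc23)C1=O` gives 1000 mL/min/kg
- compound 2 `O=C1N(c2ccncc2)CCN1c1cccc2c1cnn2-c1ccccc1F` gives 63.3 mL/min/kg
- compound 3 `O=C1NCCN1CCOc1nn(-c2ccc(F)cc2)c2ccc(F)cc12` gives 66.7 mL/min/kg

Compound 1 stands highest of the three, and its gaps to compound 3 and compound 2 both lie beyond the scatter. Compound 4 `O=C(COc1nn(-c2ccccc2F)c2ccc(F)cc12)N1CCOCC1` is unmeasured. It keeps the core of compound 1 and differs by (morpholin-4-yl)carbonyl in place of (3-methyl-2-oxoimidazolidin-1-yl)methyl on a saturated chain carbon bound to an oxygen on an aromatic ring, the change lying on a saturated chain carbon bound to an oxygen on an aromatic ring. Among the compounds with values here, no measured pair isolates this change, so the expected fall rests only on compound 1 at 1000 mL/min/kg standing far over compound 3 at 66.7 mL/min/kg. The expected step is a 5.0-fold lower number from compound 1 to compound 4 (0.70 log units; beyond the scatter). For compound 4 the estimated clearance is 200 mL/min/kg, with an expected range of 60 mL/min/kg to 700 mL/min/kg.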

Compound 4, clearance: 117 mL/min/kg
For compound 4 the middle estimate is 1.7-fold (0.23 log units) above the measured one; measured number inside the range.
By their numbers in this assay, from the lowest: compounds 2, 3 and 4 (each within the scatter of the next); then compound 1.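

In this assay, the saturated chain carbon bound to an oxygen on an aromatic ring is a position where the group carried matters: (morpholin-4-yl)carbonyl in place of (3-methyl-2-oxoimidazolidin-1-yl)methyl gives an 8.5-fold lower number from compound 1 to compound 4 (0.93 log units; beyond the scatter) on the same core. The high clearance of compound 1 is therefore not set by the shared core alone. Nothing measured here accounts for the size of this step.

The morpholine ring and the carbonyl change together here, so their shares remain unseparated. From the compounds shown here alone, how a carboxylic acid or a longer chain at this place would behave in this assay also remains open.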